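Methoxy for methyl in a small series

The compounds below may be only part of what the source reports. "The series", "measured", "known", "first", "only" and "open" are said of these compounds alone.

Compound 1 `Cc1cccc(Nc2nccc(-c3ccc(Br)cc3)n2)c1`: 71000 nM
Compound 2 `Clc1ccc(Nc2nccc(-c3ccc(Cl)cc3Cl)n2)c(Cl)c1`: 1560 nM
Compound 3 `Clc1ccc(Nc2nccc(-c3ccc(Br)cc3)n2)cc1`: 36700 nM

These numbers come from a functional assay on HeLa cells (Homo sapiens) for antiproliferative activity, read by MTT assay; a higher number here means a weaker inhibitor, a lower number a stronger inhibitor. Compound 1 stands at the top of this small range with 71000 nM, but compound 3 lies within the scatter of it. Compound 2, at 1560 nM, lies well under both of them.

Compound 4 `COc1cccc(Nc2nccc(-c3ccc(Br)cc3)n2)c1` has not been measured yet. It differs from compound 1 by a single exchange, methoxy in place of methyl on an aromatic carbon, meta to a large group.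

Going by the values given here, only one measured step touches this part of the molecule. Replacing the whole 3-methylphenyl group on nitrogen with 4-chlorophenyl gave a 1.9-fold lower number from compound 1 to compound 3 (0.29 log units; within the scatter), so for compound 4, where only the methyl itself is exchanged, no step beyond the scatter is expected in this assay. Compound 2 differs from compound 1 in more than one place and offers no clean comparison. One step is thin evidence, so the range is kept wide.

The expected change is small, and the estimated step is a 1.3-fold lower number from compound 1 to compound 4 (0.11 log units; within the scatter). The estimate for compound 4 is 55000 nM, with an expected range from 22000 nM to 130000 nM.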

Compound 4, half-maximal inhibitory concentration: 153000 nM
Compound 4: middle estimate off by 2.8-fold (0.44 log units), on the low side; measured number outside the range, above it.
By their numbers in this assay, from the lowest: compound 2; then compounds 3 and 1 (each within the scatter of the next); then compound 4.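

In this assay, exchanging only the methyl for methoxy on an aromatic carbon, meta to a large group, gives a 2.2-fold higher number from compound 1 to compound 4 (0.33 log units; beyond the scatter). Since a higher number means a weaker inhibitor, this modest step runs towards weaker activity, and it lies beyond the scatter, unlike the earlier exchange of the whole 3-methylphenyl group for 4-chlorophenyl, which gave a 1.9-fold lower number from compound 1 to compound 3 (0.29 log units; within the scatter). So this position is not indifferent to a small edit, although nothing measured here accounts for the rise in the number, and the added oxygen cannot be singled out as its source.

The compounds shown leave open whether an amine or a hydroxyl group on this same carbon would shift the number as methoxy does, and whether a longer chain such as ethoxy would raise it further. This single pair also cannot say whether methoxy in place of methyl would have a similar effect on a differently substituted compound, such as one carrying the chlorines of compound 2.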